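The source may hold more compounds than are shown below. What is called first, only, known or untested is meant among the compounds shown, and "the series" means these compounds.

Of the compounds shown here, three have been measured. Compound 1 `O=C(Nc1ccc(S(=O)(=O)N2CCOCC2)c2ccccc12)c1ccccc1` gives 7750 nM in an assay on L1.2 cells for binding affinity to C-C chemokine receptor type 8 (Homo sapiens); on this read-out higher numbers stand for weaker inhibition and lower numbers for stronger inhibition. Compound 2 `CCOC(=O)N1CCC(NS(=O)(=O)c2ccc(C(=O)NC3CCCCC3)c3ccccc23)CC1` gives 9.5 nM in this assay. Compound 3 `COCC(=O)N1CCC(NS(=O)(=O)c2ccc(NC(=O)c3ccccc3C)c3ccccc23)CC1` gives 15.8 nM in this assay. On these numbers compound 3 stands second highest of the three; its nearest neighbour is compound 2, whose number lies within the scatter of it, and its furthest is compound 1, whose far higher number lies beyond the scatter. Going by the values given here, no pair of measured compounds differs in one place only, so no single step has yet been read off.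

Compound 4 `Cc1ccccc1C(=O)Nc1ccc(S(=O)(=O)NC2CCN(C(=O)N3CCC3)CC2)c2ccccc12` differs from compound 3 in one place: azetidin-1-yl in place of methoxymethyl on a carbonyl carbon. Nothing in the measured compounds speaks to this exchange, so the expected step from compound 3 is small, and the estimated step of a 1.0-fold higher number from compound 3 to compound 4 (0.01 log units; within the scatter) is expected to remain within the scatter. Compound 4 is therefore estimated at 16 nM, with a range from 5 nM to 50 nM.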

Compound 4, inhibition constant: 3.5 nM
For compound 4 the middle estimate is 4.6-fold (0.66 log units) above the measured one; the measured number lies below the stated range.
By their numbers in this assay, from the lowest: compound 4; then compounds 2 and 3 (each within the scatter of the next); then compound 1.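

Going by these compounds alone, this is the first single change that can be read. In this assay, azetidin-1-yl in place of methoxymethyl on a carbonyl carbon gives a 4.5-fold lower number from compound 3 to compound 4 (0.65 log units; beyond the scatter), so what this carbonyl carries does affect the number, and the change lies beyond the scatter. The exchange also removes the hydrogen-bond acceptor counted on methoxymethyl and brings in a four-membered non-aromatic ring, and the number still falls, so that acceptor is not required for a low number here. Nothing in the data explains why this exchange lowers the number.

The compounds shown leave open whether the ring itself matters or only the ring nitrogen on the carbonyl, which a dimethylamino or a pyrrolidin-1-yl group would test. Also open, going by these compounds, is whether the same exchange would act alike on the core of compound 2.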